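Coumarin Side Chain Swap: From Urea to Hydroxyethyl

The source may hold more compounds than are shown below. What is called first, only, known or untested is meant among the compounds shown, and "the series" means these compounds.

Within the data shown here, compound 2 `CCNC(=O)Nc1cc(=O)oc2cc(OCc3cccc(Cl)c3)ccc12` is the lower of the two numbers measured so far in an assay on brain (strain Sprague-Dawley) for inhibition of Amine oxidase [flavin-containing] B (Rattus norvegicus), read by spectrophotometry (on this read-out lower numbers stand for stronger inhibition and higher numbers for weaker inhibition), where compound 2 gives 31600 nM. Among the measured compounds shown here, its only neighbour, compound 1 `O=C(O)c1cc(=O)oc2cc(OCc3cccc(Cl)c3)ccc12`, gives 100000 nM in this assay; the change a 3.2-fold lower number from compound 1 to compound 2 (0.50 log units; beyond the scatter) shows that replacing the carboxy group with the urea-type substituent brought a modest gain. Compound 3 `O=c1cc(CCO)c2ccc(OCc3cccc(Cl)c3)cc2o1` differs from compound 2 at the same position, (2-hydroxyethyl in place of (ethylcarbamoyl)amino on an aromatic carbon). For the measured compounds named here, the one measured step concerns this position but a different pair of groups, so it gives only loose guidance: the position tolerates change without collapsing, yet nothing shows a further gain. Compound 3 is therefore expected to land near compound 2, with an estimated step of a 1.1-fold higher number from compound 2 to compound 3 (0.04 log units; within the scatter) in this assay. The estimate for compound 3 in this assay is 35000 nM, within a range from 8000 nM to 150000 nM.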

Compound 3, half-maximal inhibitory concentration: 7.41 nM
For compound 3 the middle estimate is 4700-fold (3.67 log units) above the measured one; the whole stated range lies above it.
By their numbers in this assay, from the lowest: compound 3; then compound 2; then compound 1.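

In this assay this position proves far more decisive than the earlier pair suggested: putting 2-hydroxyethyl in place of (ethylcarbamoyl)amino gives a 4300-fold lower number from compound 2 to compound 3 (3.63 log units; beyond the scatter) and putting it in place of carboxy gives a 13000-fold lower number from compound 1 to compound 3 (4.13 log units; beyond the scatter) on the same core. The group on this aromatic carbon, opposite the ring oxygen, can therefore swing the read-out enormously while the rest of the molecule stays unchanged. Nothing measured here explains why this change has so large an effect.

What remains open is whether the gain depends on the hydroxyl at the end of the chain, on the chain itself, or on both, since compound 3 is the only compound of its kind shown. A plain ethyl, a 2-methoxyethyl, a 3-hydroxypropyl or a 2-aminoethyl group on this carbon would help separate these possibilities.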